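Swapping pyridin-2-yl for pyridin-3-yl on compound 3

The source may report more compounds than this note shows. Statements on the series, on what has been measured and on what is new or still open speak of the compounds shown alone.

compound 1 `CC(=O)c1ccc(OCCCCN2CCN(c3cccnc3)CC2)cc1` gives 24.2 nM
compound 2 `CCC(C)(C)c1ccc(OCCCCN2CCN(c3cccnc3)CC2)cc1` gives 3.23 nM
compound 3 `CC(C)(C)c1ccc(OCCCCN2CCN(c3ccccn3)CC2)cc1` gives 11.9 nM

All three values come from a functional assay on L5178Y cells (Mus musculus) for antiproliferative activity, read by MTT assay (on this read-out higher numbers stand for weaker inhibition and lower numbers for stronger inhibition), and compound 3 sits between the other two, with both gaps beyond the usual scatter. Compound 4 `CC(C)(C)c1ccc(OCCCCN2CCN(c3cccnc3)CC2)cc1` differs from compound 3 in one group (pyridin-3-yl in place of pyridin-2-yl on an amine nitrogen in a ring). Going by the values given here, the only measured step of a 7.5-fold lower number from compound 1 to compound 2 (0.87 log units; beyond the scatter) was modest but lies at another place in the molecule, so no measured pair tests this swap. Compound 2 at 3.23 nM also carries pyridin-3-yl, which gives a weak hint toward a lower number. The expected change in this assay is a 1.7-fold lower number from compound 3 to compound 4 (0.23 log units; within the scatter) and so stays small. Compound 4 is estimated at 7 nM with an expected range from 2.5 nM to 16 nM for now.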

Compound 4, half-maximal inhibitory concentration: 5.48 nM
Compound 4: the middle estimate sits 1.3-fold (0.11 log units) above what was measured; low and high end bracket the measured number.
By their numbers in this assay, from the lowest: compounds 2 and 4 (each within the scatter of the next); then compound 3; then compound 1.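

In this assay, pyridin-3-yl in place of pyridin-2-yl on an amine nitrogen in a ring gives a 2.2-fold lower number from compound 3 to compound 4 (0.34 log units; beyond the scatter), so this first measured test of the swap shows that the place of the pyridine nitrogen matters, if modestly. With pyridin-3-yl kept, tert-butyl in place of acetyl gives a 4.4-fold lower number from compound 1 to compound 4 (0.65 log units; beyond the scatter), whereas tert-butyl against 1,1-dimethylpropyl gives only a 1.7-fold higher number from compound 2 to compound 4 (0.23 log units; within the scatter). No measurement shown here explains the effect of the swap. Going by these compounds, whether the swap acts alike with acetyl on the other end, and how pyridin-4-yl or phenyl on that nitrogen would compare, remains open.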